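The source may hold more compounds than are shown below. What is called first, only, known or untested is meant among the compounds shown, and "the series" means these compounds.

In a functional assay on A549 cells (Homo sapiens) for inhibition, read by CCK-8 assay, with a stated time of 72 h, tested at 2 uM (a higher number here means more inhibition of growth at the concentration tested, a lower number less inhibition of growth), compound 1 (`Nc1ccccc1NC(=O)c1ccc(CSc2cccc(F)c2)cc1`) gives 46.9%. Compound 2 (`Nc1ccccc1NC(=O)/C=C/c1ccc(CSc2ccc(C(F)(F)F)cn2)cc1`) gives 51.7%, and compound 3 (`Nc1ccccc1NC(=O)/C=C/c1ccc(CSc2ccc(F)cc2)cc1`) gives 51.2%. All three numbers lie within the scatter of one another, so compound 1 does not stand apart from the other two.

Compound 4 (`Nc1ccccc1NC(=O)c1ccc(CSCCc2ccccc2)cc1`) is still unmeasured. It differs from compound 1 by phenethyl in place of 3-fluorophenyl on a sulfur.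

Within the data shown here, only one measured step changes the group on a sulfur: a number 0.5 percentage points lower from compound 2 to compound 3 (within the scatter). Among the measured compounds shown here, that step is small, but it comes from a core other than that of compound 1, and no measured compound carries phenethyl, so it is only a weak guide. On this limited evidence, no shift beyond the scatter is expected in this assay, and no direction is favoured with any confidence.

The estimated step is a number 1.9 percentage points lower from compound 1 to compound 4 (within the scatter), which is expected to stay within the scatter. For compound 4, the expected value is 45%, with an estimated range of 29% to 60%.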

Compound 4, percent growth inhibition at one concentration: 44.9%
For compound 4 the middle estimate is 0.1 percentage points above the measured one; measured number inside the range.
By their numbers in this assay, from the lowest: compounds 4, 1, 3 and 2 (each within the scatter of the next).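

With the step on the core of compound 1, a number 2 percentage points lower from compound 1 to compound 4 (within the scatter), this position now has a change in this assay that alters more than a ring substituent: the fluorine goes and a carbon chain enters in the group on the sulfur. Together with a number 0.5 percentage points lower from compound 2 to compound 3 (within the scatter), on a different core, this gives two changes on a sulfur, and neither moves the number beyond the scatter, so no preference between these groups can be read at this position. No available measurement offers an explanation for this result.

Still open, on these data alone, is whether a group of another kind on the sulfur, such as an amine, a carboxylic acid or a chain longer than phenethyl, would give a step beyond the scatter. Also open, as far as these compounds go, is whether phenethyl would give a similar number on the core of compound 3.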